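The source may report more compounds than this note shows. Statements on the series, on what has been measured and on what is new or still open speak of the compounds shown alone.

- Compound 1 `CCCCCCCCCCCCCCNC(=O)[C@H](CO)NC(=O)C1CCCCC1`: 11500 nM
- Compound 2 `CCCCCCCCCCCCCCNC(=O)[C@H](CO)NCc1ccccc1`: 10500 nM

In a functional assay on MDA-MB-231 cells (Homo sapiens) for inhibition, read by microscopy and colony formation, with a stated time of 10 days (a higher number here means a weaker inhibitor, a lower number a stronger inhibitor), compound 2 gives 10500 nM, which lies within the scatter of compound 1 at 11500 nM. Only these two numbers are available, so compound 2 has no clear rank. Compound 3 `CCCCCCCCCCCCCCNC(=O)[C@H](CO)/N=C/c1ccccc1` remains unmeasured. It differs from compound 2 by a group of 8 heavy atoms (7 carbon, 1 nitrogen; one six-membered aromatic ring of carbon only) in place of a group of 8 heavy atoms (7 carbon, 1 nitrogen; one six-membered aromatic ring of carbon only), on a saturated chain carbon bound to a carbonyl carbon and a saturated chain carbon. The swapped group sits on a saturated chain carbon bound to a carbonyl carbon and a saturated chain carbon, and the heavy-atom count stays the same.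

Within the data shown here, the one measured step, a 1.1-fold lower number from compound 1 to compound 2 (0.04 log units; within the scatter), also changed the group on this nitrogen, and it stayed within the scatter. Among the measured compounds shown here, it is only indirect evidence, since no measured compound carries the entering group. An estimated 1.1-fold lower number from compound 2 to compound 3 (0.02 log units; within the scatter) is therefore expected, meaning no change beyond the scatter. For compound 3 the estimated value is 10000 nM, with an expected range of 5000 nM to 20000 nM.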

Compound 3, half-maximal inhibitory concentration: 2400 nM
Estimate against measurement, compound 3: 4.2-fold (0.62 log units) above; the measured number lies below the stated range.
By their numbers in this assay, from the lowest: compound 3; then compounds 2 and 1 (each within the scatter of the next).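

In this assay, the change shows that this position is not indifferent to what stands on it, as the earlier step within the scatter had left possible: a 4.4-fold lower number from compound 2 to compound 3 (0.64 log units; beyond the scatter) comes with the same heavy-atom count and the same six-membered aromatic ring of carbon only. What is counted as different is a double bond outside aromatic rings and the absence of a hydrogen-bond donor, and the step against the cyclohexylcarbonyl compound, a 4.8-fold lower number from compound 1 to compound 3 (0.68 log units; beyond the scatter), also lies beyond the scatter. Nothing available explains this difference.

The compounds shown do not separate the double bond from the missing hydrogen-bond donor as the feature tied to the lower number. They also leave open how the number would respond to a pyridine ring in place of the benzene ring, or to a shorter chain in place of the long one.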